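Triazolylmethyl lactams on a fused quinoxaline core: inactive pair

The compounds below may be only part of what the source reports. "The series", "measured", "known", "first", "only" and "open" are said of these compounds alone.

Working notes on the series. Two compounds have been run in a functional assay on HepG2 cells (Homo sapiens) for antiproliferative activity, read by MTT assay, with a stated time of 48 h; on this read-out higher numbers stand for weaker inhibition and lower numbers for stronger inhibition. Compound 1 `COc1ccccc1-n1nncc1CN1C(=O)C2(C(C#N)=C(N)Oc3c2c2nc4ccccc4nc2c2ccccc32)c2ccccc21` carries the 2-methoxyphenyl group on the triazole and a core without the aromatic amine. In this assay compound 1 reports only an assay limit, > 50000 nM, not a number. Compound 2 `Cc1cccc(-n2nncc2CN2C(=O)C3(C(C#N)=C(N)Oc4c(N)cc5nc6ccccc6nc5c43)c3ccccc32)c1` bears the amine-substituted core and a 3-methylphenyl group on the triazole. In this assay compound 2 likewise reports only a limit, > 50000 nM, and not a measured value. Compound 2 therefore stands at the edge of what the assay can report, and every value shown so far sits there: the limit of > 50000 nM in this assay, at which 2 of the 2 values shown sit.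

Compound 3 `COc1ccccc1-n1nncc1CN1C(=O)C2(C(C#N)=C(N)Oc3c(N)cc4nc5ccccc5nc4c32)c2ccccc21` is the next compound to be measured. It keeps the amine-substituted core of compound 2 and differs only on the triazole: 2-methoxyphenyl in place of 3-methylphenyl on an aromatic nitrogen. Within the data shown here, no measured pair differs in one place, so no step size is known for this change. Given that compound 1 and compound 2 both sit at the limit, the expectation is no step beyond the scatter, a step that the limit leaves unreadable from compound 2 to compound 3. Compound 3 is estimated at 60000 nM, within 20000 nM to 200000 nM, most likely reported as a limit again.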

Compound 3, half-maximal inhibitory concentration: > 50000 nM
Compound 3: a limit, no number (the forecaster's own chance of this, stated with the estimate: 80%); the middle value is on the limit's open side.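

No step can be read between compound 2 and compound 3, as both report only limits for 2-methoxyphenyl in place of 3-methylphenyl on an aromatic nitrogen: the limit of > 50000 nM in this assay, at which 3 of the 3 values shown sit.

The compounds shown leave open how the group on the triazole or the amine on the core bears on activity in this assay, with no measured number among them.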